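Saturated amine versus arylamino at the chloro-bearing core

This account rests on a few compounds, and the source may have more. Where it says the series, first, only, none or still open, it means among the compounds named here.

Measured compounds:
- compound 1 `CN1CCN(c2nc(Cl)nc3c2ncn3Cc2ccc(C(=O)Nc3ccccc3N)cc2)CC1`: 6160 nM
- compound 2 `Nc1ccccc1NC(=O)c1ccc(Cn2cnc3c(Nc4ccccc4)nc(Cl)nc32)cc1`: 5740 nM
- compound 3 `Cc1ccc(Nc2nc(Cl)nc3c2ncn3Cc2ccc(C(=O)Nc3ccccc3N)cc2)cc1`: 1590 nM

All three numbers come from a functional assay on NCI-H460 cells (Homo sapiens) for antiproliferative activity, read by CCK-8 assay, with a stated time of 72 h; a higher number here means a weaker inhibitor, a lower number a stronger inhibitor. Compound 3 stands with the lowest number of the three; the others differ from it by more than the scatter, as the comparisons show, so within this small set compound 3 is the strongest inhibitor.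

Compound 4 `CC1CCN(c2nc(Cl)nc3c2ncn3Cc2ccc(C(=O)Nc3ccccc3N)cc2)CC1` has not yet been measured. It differs from compound 3 in one place: 4-methylpiperidin-1-yl in place of (4-methylphenyl)amino on an aromatic carbon. Among the measured compounds shown here, the change removes the arylamino group and puts a saturated ring amine in its place, which is the same kind of swap, run backwards, as the one between compound 1 and compound 3. That step was a 3.9-fold lower number from compound 1 to compound 3 (0.59 log units; beyond the scatter). The step of a 3.6-fold lower number from compound 2 to compound 3 (0.56 log units; beyond the scatter) shows that the methyl on the aryl ring contributed part of that gain, while a 1.1-fold lower number from compound 1 to compound 2 (0.03 log units; within the scatter) shows the unmethylated arylamino and the saturated amine giving much the same number. Compound 4 carries a saturated amine with a methyl but no aryl ring, so the expectation for compound 4 is a number close to that of compound 1, meaning a modest rise against compound 3: a 3.1-fold higher number from compound 3 to compound 4 (0.50 log units; beyond the scatter) is expected. Compound 4 is therefore estimated at 5000 nM, with a range of 2000 nM to 12000 nM.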

Compound 4, half-maximal inhibitory concentration: 7400 nM
For compound 4 the middle estimate is 1.5-fold (0.17 log units) below the measured one; the range from low to high includes it.
By their numbers in this assay, from the lowest: compound 3; then compounds 2, 1 and 4 (each within the scatter of the next).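

In this assay, the step of a 4.7-fold higher number from compound 3 to compound 4 (0.67 log units; beyond the scatter) shows that a methyl-bearing six-membered ring at this position does not by itself preserve the low number of compound 3: the 4-methylpiperidin-1-yl group does not match the (4-methylphenyl)amino group. The steps of a 1.3-fold higher number from compound 2 to compound 4 (0.11 log units; within the scatter) and a 1.2-fold higher number from compound 1 to compound 4 (0.08 log units; within the scatter) both lie within the scatter, so compound 4 cannot be separated from either compound 2 or compound 1, and among the four compounds only compound 3 stands apart. Nothing measured on these compounds accounts for this separation.

The compounds shown leave open whether the methyl could be replaced on the aryl ring, for example by methoxy or chloro, and whether the amino hydrogen of the (4-methylphenyl)amino group matters, which an N-methyl-N-(4-methylphenyl)amino group would test. They also leave open how other saturated amines, such as morpholine or unsubstituted piperidine, would behave at this aromatic carbon on the shared core.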